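A few compounds are considered here, and "the series" means these few. Any claim that something is new, unique, unknown or untested is made for them only; others in the source may bear on it.

Measured compounds:
compound 1, `COc1cc(-c2cc(/C=C/C(=O)c3ccc(N)cc3)[nH]n2)cc(OC)c1OC`, 7530 nM
compound 2, `COc1cc(-c2cc(/C=C/C(=O)c3ccc(Cl)c(Cl)c3)[nH]n2)cc(OC)c1OC`, 34100 nM
compound 3, `COc1ccc(-c2cc(/C=C/C(=O)c3cc(OC)c(OC)c(OC)c3)[nH]n2)cc1OC`, 7700 nM

These three compounds share a core and were tested in a functional assay on SK-MEL-2 cells (Homo sapiens) for inhibition, read by sulforhodamine B assay, with a stated time of 48 h; a lower number here means a stronger inhibitor of growth, a higher number a weaker inhibitor of growth. Among them compound 2 gives the highest number, so it is the weakest inhibitor of growth of the three; the nearest is compound 3, whose number is lower, and the furthest is compound 1. For the measured compounds named here, the one step measured between single-change neighbours runs a 4.5-fold higher number from compound 1 to compound 2 (0.66 log units; beyond the scatter), a modest move towards weaker inhibition when a chlorine-bearing ring replaced an amino-bearing one.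

Compound 4, `COc1ccc(C(=O)/C=C/c2cc(-c3cc(OC)c(OC)c(OC)c3)n[nH]2)cc1`, has not yet been measured. It differs from compound 2 in one place: 4-methoxyphenyl in place of 3,4-dichlorophenyl on a carbonyl carbon. Going by the values given here, only the step from compound 1 to compound 2 bears on this change, and it shows that swapping the ring on the carbonyl carbon can shift the number by a modest amount. Since compound 4 again carries an oxygen-bearing ring at that place, and compound 1 and compound 3 with oxygen- or nitrogen-bearing rings gave lower numbers, the expectation is a modest move back towards stronger inhibition, a 3.8-fold lower number from compound 2 to compound 4 (0.58 log units; beyond the scatter). Compound 4 is estimated at 9000 nM, with a likely range from 3500 nM to 25000 nM.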

Compound 4, concentration for total growth inhibition: 19600 nM
Beside the measured number, compound 4's estimate is 2.2-fold (0.34 log units) below it, within the range that was stated.
By their numbers in this assay, from the lowest: compounds 1 and 3 (each within the scatter of the next); then compounds 4 and 2 (each within the scatter of the next).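

In this assay putting 4-methoxyphenyl in place of 3,4-dichlorophenyl on a carbonyl carbon gives a 1.7-fold lower number from compound 2 to compound 4 (0.24 log units; within the scatter) and so does not separate these two rings at this position. Methoxy in place of amino on an aromatic carbon does register, with a 2.6-fold higher number from compound 1 to compound 4 (0.42 log units; beyond the scatter) as the result. Together with a 4.5-fold higher number from compound 1 to compound 2 (0.66 log units; beyond the scatter) as the earlier step, this leaves compound 1 apart from both compound 2 and compound 4, so an oxygen-bearing group on this ring does not by itself bring the number back towards that of the amino compound.

On these data alone, whether a hydroxy or a dimethylamino group on this ring would stay with the amino group of compound 1 remains open. No measurement shown here explains why the amino compound stands apart.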